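The source may hold more compounds than are shown below. What is called first, only, known or untested is meant among the compounds shown, and "the series" means these compounds.

Measured compounds:
- compound 1, `COc1cc2c(Oc3ccc(NC(=O)c4cc(-c5ccccc5)ccn4)cc3F)ccnc2cc1OCCCN1CCN(C)CC1`: 340 nM
- compound 2, `COc1cc2c(Oc3ccc(NC(=O)c4cc(-c5ccccc5C)ccn4)cc3F)ccnc2cc1OCCCN1CCN(C)CC1`: 1330 nM
- compound 3, `COc1cc2c(Oc3ccc(NC(=O)c4nccc(-c5ccccc5)n4)cc3F)ccnc2cc1OCCCN1CCCCC1`: "not determined" (no result reported)

In a functional assay on A549 cells (Homo sapiens) for cytotoxicity, read by MTT assay, with a stated time of 72 h (a lower number here means a stronger inhibitor, a higher number a weaker inhibitor), compound 1 gives 340 nM, and compound 2 gives 1330 nM. The two share one core and differ by methyl in place of hydrogen on an aromatic carbon; this change made a 3.9-fold higher number from compound 1 to compound 2 (0.59 log units; beyond the scatter). Compound 3 carries a different core, and the difference between the two cores is not broken down here. For compound 3 no single number is available in this assay.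

Compound 4, `COc1cc2c(Oc3ccc(NC(=O)c4nccc(-c5ccc(C)cc5)n4)cc3F)ccnc2cc1OCCCN1CCCCC1`, is built from compound 3 by methyl in place of hydrogen on an aromatic carbon. Among the compounds with values here, this is the same kind of change as the one from compound 1 to compound 2, though the two do not sit alike: in compound 2 the methyl stands ortho to a large group, while in compound 4 it stands para to a large group, and the surrounding core is another one. With no number for compound 3, the expectation for compound 4 cannot be anchored to its own parent and rests instead on the level of compound 1, 340 nM, and the step it took to compound 2, a 3.9-fold higher number from compound 1 to compound 2 (0.59 log units; beyond the scatter). The account therefore expects compound 4 to land in the same general region as compound 2, with a wide band to allow for the other core and the other place of the methyl. The estimate for compound 4 in this assay is 700 nM, expected to fall between 150 nM and 3500 nM.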

Compound 4, half-maximal inhibitory concentration: 900 nM
Estimate against measurement, compound 4: 1.3-fold (0.11 log units) below, and the stated range covers the measured number.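

No number is shown for compound 3 in this assay, so no step from compound 3 to compound 4 can be read, and compound 4 at 900 nM stands without a parent value. The compounds shown leave open whether phenyl to 4-methylphenyl shifts the number on this core as a 3.9-fold higher number from compound 1 to compound 2 (0.59 log units; beyond the scatter) did on the other. No data shown here offer an explanation for the value of compound 4.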